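Methoxy in place of trifluoromethyl: expectation for compound 4

The compounds below may be only part of what the source reports. "The series", "measured", "known", "first", "only" and "open" are said of these compounds alone.

In an ADME assay on the whole organism (Rattus norvegicus) for pharmacokinetics, read by HPLC, at a dose of 3 mg/kg by the oral route (a higher number here means more compound in the circulation at the dose given, a lower number less compound in the circulation), compound 1 (`N#Cc1cc(C(=O)N2CCc3ccccc32)cc(I)c1O`) gives 15200 nM and compound 2 (`N#Cc1cc(C(=O)N2CSc3ccccc32)cc(C(F)(F)F)c1O`) gives 8990 nM while compound 3 (`O=C(c1cc(Cl)c(O)c(C(F)(F)F)c1)N1CS(=O)(=O)c2ccccc21`) gives 16400 nM with no separation from either, since all three values lie within the scatter of one another. Compound 4 (`COc1cc(C(=O)N2CS(=O)(=O)c3ccccc32)cc(Cl)c1O`) has methoxy in place of trifluoromethyl on an aromatic carbon, ortho to a hydroxy group (methoxy in place of trifluoromethyl on an aromatic carbon). Among the compounds with values here, no measured pair differs in one place only, so the data give no direct size for this change. Compound 1 carries no trifluoromethyl and still gives 15200 nM in the same range, so no step beyond the scatter is expected, with a slight lean to a lower number. The expected change is a 1.6-fold lower number from compound 3 to compound 4 (0.21 log units; within the scatter) and remains an estimate. For compound 4 the estimate is 10000 nM with an expected range of 3500 nM to 22000 nM as the likely span.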

Compound 4, maximal plasma concentration: 3000 nM
Compound 4: the middle estimate sits 3.3-fold (0.52 log units) above what was measured; measured number outside the range, below it.
By their numbers in this assay, from the lowest: compound 4; then compounds 2, 1 and 3 (each within the scatter of the next).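

In this assay, within the data shown here, the change to methoxy in place of trifluoromethyl on an aromatic carbon, ortho to a hydroxy group, gives a 5.5-fold lower number from compound 3 to compound 4 (0.74 log units; beyond the scatter) and is the only step so far that can be read. This position is therefore not indifferent to its group, at least with the chloro group and the rest of compound 3 held constant. Nothing on hand explains the step.

As far as these compounds go, whether the drop follows from losing trifluoromethyl or from gaining methoxy stays open, and a methyl or a fluoro group at this place would help separate the two. Whether the step carries over to the cores of compound 1 and compound 2 is also unknown.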